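Changing the aryl group on a shared core

A few compounds are considered here, and "the series" means these few. Any claim that something is new, unique, unknown or untested is made for them only; others in the source may bear on it.

Compound 1 `O=c1ccc2cc(OCc3cn(-c4cccc([N+](=O)[O-])c4)nn3)ccc2o1` — 20500 nM
Compound 2 `O=c1ccc2cc(OCc3cn(-c4ccc(Cl)c(Cl)c4)nn3)ccc2o1` — 47800 nM
Compound 3 `O=c1ccc2cc(OCc3cn(-c4ccc([N+](=O)[O-])cc4)nn3)ccc2o1` — 46000 nM

In a functional assay on HL-60 cells (Homo sapiens) for cytotoxicity, read by MTT assay, with a stated time of 48 h (a higher number here means a weaker inhibitor, a lower number a stronger inhibitor), compound 3 stands second highest of the three numbers. Its nearest neighbour is compound 2, with a 1.0-fold lower number from compound 2 to compound 3 (0.02 log units; within the scatter); its furthest is compound 1, with a 2.2-fold higher number from compound 1 to compound 3 (0.35 log units; beyond the scatter). Compound 4 `COc1ccccc1-n1cc(COc2ccc3oc(=O)ccc3c2)nn1` differs from compound 3 by 2-methoxyphenyl in place of 4-nitrophenyl on an aromatic nitrogen. Among the measured compounds shown here, every measured step so far also changed only the aryl group on that nitrogen: a 2.3-fold higher number from compound 1 to compound 2 (0.37 log units; beyond the scatter), a 2.2-fold higher number from compound 1 to compound 3 (0.35 log units; beyond the scatter) and a 1.0-fold lower number from compound 2 to compound 3 (0.02 log units; within the scatter). None was more than modest, so compound 4 is expected to land near compound 3, with a step of a 1.3-fold lower number from compound 3 to compound 4 (0.12 log units; within the scatter) and no clear direction. Compound 4 is thus estimated at 35000 nM, in a range from 14000 nM to 90000 nM.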

Compound 4, half-maximal inhibitory concentration: 55200 nM
Estimate against measurement, compound 4: 1.6-fold (0.20 log units) below; the range from low to high includes it.
By their numbers in this assay, from the lowest: compound 1; then compounds 3, 2 and 4 (each within the scatter of the next).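

In this assay the 2-methoxyphenyl group falls in with the 4-nitrophenyl and 3,4-dichlorophenyl groups on the aromatic nitrogen, with a 1.2-fold higher number from compound 3 to compound 4 (0.08 log units; within the scatter) and a 1.2-fold higher number from compound 2 to compound 4 (0.06 log units; within the scatter), so swapping among these three aryl groups leaves the number unmoved. Only the 3-nitrophenyl group stands apart, with a 2.7-fold higher number from compound 1 to compound 4 (0.43 log units; beyond the scatter), and it is now separated beyond the scatter from all three others. Nothing available explains this grouping. The compounds shown leave open how an aryl group carrying an amine or a carboxylic acid would behave on that nitrogen. They also leave open whether a benzyl group there would give a number lower than that of compound 1.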